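Benzyl halogen swap: compound 3 to compound 4

The compounds below may be only part of what the source reports. "The series", "measured", "known", "first", "only" and "open" are said of these compounds alone.

Measured so far:
compound 1 `O=c1ccc(-c2ccc3cn[nH]c3c2)cn1Cc1ccccc1C(F)(F)F`, 133 nM
compound 2 `Nc1n[nH]c2cc(-c3ccc(=O)n(Cc4ccccc4F)c3)ccc12`, 12 nM
compound 3 `O=c1ccc(-c2ccc3cn[nH]c3c2)cn1Cc1ccccc1Cl`, 80 nM

In an assay for inhibition of MAP kinase-interacting serine/threonine-protein kinase 1 (Homo sapiens), read by luminescence and ADP-Glo, with a stated time of 2 h (a higher number here means a weaker inhibitor, a lower number a stronger inhibitor), compound 3 stands second highest of the three numbers. Among the compounds with values here, compound 1 is nearest and compound 2 furthest; the gap to compound 2 lies beyond the scatter, but compound 2 carries a different core, so no single-point step connects it to compound 3. Compound 4 `O=c1ccc(-c2ccc3cn[nH]c3c2)cn1Cc1ccccc1F` is not yet measured; it differs from compound 3 by fluoro in place of chloro on an aromatic carbon. Within the data shown here, the one measured step at this place, a 1.7-fold lower number from compound 1 to compound 3 (0.22 log units; within the scatter), was within the scatter. A step of similar size is therefore expected here, with no direction beyond the scatter. For compound 4 the estimate in this assay is 110 nM, range 50 nM to 250 nM, meaning a 1.4-fold higher number from compound 3 to compound 4 (0.14 log units; within the scatter).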

Compound 4, half-maximal inhibitory concentration: 47 nM
Estimate against measurement, compound 4: 2.3-fold (0.37 log units) above, and the stated range ends above it.
By their numbers in this assay, from the lowest: compound 2; then compounds 4, 3 and 1 (each within the scatter of the next, the first and the last beyond it).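

In this assay, within the data shown here, fluoro and chloro at this place cannot be told apart (a 1.7-fold lower number from compound 3 to compound 4 (0.23 log units; within the scatter)), whereas fluoro in place of trifluoromethyl gives the first step here that lies beyond the scatter (a 2.8-fold lower number from compound 1 to compound 4 (0.45 log units; beyond the scatter)). Compound 4 also pairs with compound 2 and isolates the amino group on the core, whose loss gives a step beyond the scatter (a 3.9-fold higher number from compound 2 to compound 4 (0.59 log units; beyond the scatter)). No measurement at hand accounts for either step.

As far as these compounds go, whether amino gives a similar step alongside chloro or trifluoromethyl remains open. So does how methoxy or nitrile would read at this place.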